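Amide replacement in a triazole series of ghrelin receptor antagonists

The compounds below may be only part of what the source reports. "The series", "measured", "known", "first", "only" and "open" are said of these compounds alone.

Measured so far:
compound 1, `COc1ccc(Cn2c(CCc3ccccc3)nnc2[C@H](NC(=O)C(C)(C)N)c2c[nH]c3ccccc23)cc1`: 5 nM
compound 2, `CCc1ccc(-n2c(CCc3c[nH]c4ccccc34)nnc2[C@H](NC(=O)c2ccccn2)c2c[nH]c3ccccc23)cc1`: 129 nM

In a functional assay on CHO cells for antagonist activity at growth hormone secretagogue receptor type 1 (Homo sapiens) (a lower number here means a stronger inhibitor, a higher number a weaker inhibitor), compound 1 gives 5 nM and has the lowest number of the two measured compounds. Compound 2 gives 129 nM in this assay, a gap beyond the scatter, but the two structures differ in several places at once, so nothing can be read from that pair about any single change.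

Compound 3, `COc1ccc(Cn2c(CCc3ccccc3)nnc2[C@H](NC(=O)c2ccccn2)c2c[nH]c3ccccc23)cc1`, is not yet measured. Among the measured compounds shown here, its only difference from compound 1 is pyridin-2-yl in place of 1-amino-1-methylethyl on a carbonyl carbon. The (pyridin-2-yl)carbonyl amide of compound 3 is also present in compound 2, whose value of 129 nM is the only hint available, though it is a weak one given the other differences in compound 2.

The step from compound 1 to compound 3 is expected to lie beyond the scatter and to raise the number, by about an 8.0-fold higher number from compound 1 to compound 3 (0.90 log units; beyond the scatter). Compound 3 is therefore estimated at 40 nM in this assay, with a range from 8 nM to 200 nM.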

Compound 3, antagonist equilibrium constant: 12 nM
Beside the measured number, compound 3's estimate is 3.3-fold (0.52 log units) above it; the measured number falls inside the stated range.
By their numbers in this assay, from the lowest: compound 1; then compound 3; then compound 2.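

In this assay, the series now has its first comparison that changes only one place: pyridin-2-yl in place of 1-amino-1-methylethyl on a carbonyl carbon gives a 2.4-fold higher number from compound 1 to compound 3 (0.38 log units; beyond the scatter), a modest step that lies beyond the scatter. The change swaps a group with no ring and a hydrogen-bond donor for a six-membered aromatic ring with no hydrogen-bond donor, yet compound 3 still gives 12 nM, so on the core of compound 1 this position accepts two quite different groups with only a modest loss. No measurement available here explains the size of this step.

Only one replacement has been compared at this position, so the compounds shown cannot separate the contribution of the ring from that of its nitrogen; a phenyl or pyridin-3-yl on the same carbonyl carbon would address this. Compound 2 shares the (pyridin-2-yl)carbonyl amide but differs from compound 3 in other places, so it cannot show whether the step holds with other groups elsewhere on the core.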